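The compounds below may be only part of what the source reports. "The series", "measured", "known", "first", "only" and "open" are said of these compounds alone.

In a functional assay on T47D cells (Homo sapiens) for cytotoxicity, read by colorimetric assay and MTT assay (on this read-out lower numbers stand for stronger inhibition and higher numbers for weaker inhibition), compound 1 (`CCN(CC)C(=O)Cn1c(=O)c(-c2ccc(OC)cc2)cc2c(OC)cc(OC)cc21`) gives 10000 nM, compound 2 (`COc1ccc(-c2cc3c(OC)cc(OC)cc3n(CC#N)c2=O)cc1`) gives 10000 nM and compound 3 (`COC(=O)CCn1c(=O)c(-c2ccc(OC)cc2)cc2c(OC)cc(OC)cc21`) gives 10000 nM, so compound 3 stands level with the other two. Compound 4 (`CCN(CC)C(=O)CCn1c(=O)c(-c2ccc(OC)cc2)cc2c(OC)cc(OC)cc21`) differs from compound 3 by one change: diethylamino in place of methoxy on a carbonyl carbon. In words, this is diethylamino in place of methoxy on a carbonyl carbon, which turns 2-(methoxycarbonyl)ethyl into 2-(diethylcarbamoyl)ethyl.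

For the measured compounds named here, three measured steps bear on this, all exchanging the group on a saturated chain carbon bound to an aromatic nitrogen: no change at the digits printed from compound 1 to compound 3 (within the scatter), which also trades a diethylcarbamoyl group against a methoxycarbonyl-bearing chain; no change at the digits printed from compound 1 to compound 2 (within the scatter); and no change at the digits printed from compound 2 to compound 3 (within the scatter). None of them goes beyond the scatter. With compound 3 at 10000 nM and no measured change at this chain showing any response, no shift beyond the scatter is expected in this assay, in either direction. The expected step is no change at the digits printed from compound 3 to compound 4 (within the scatter). For compound 4 the estimated value is 10000 nM, with an expected range of 4000 nM to 20000 nM.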

Compound 4, half-maximal inhibitory concentration: 10000 nM
Beside the measured number, compound 4's estimate shows no gap at the digits printed; measured number inside the range.
By their numbers in this assay, from the lowest: compounds 1, 2, 3 and 4 (each within the scatter of the next).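

In this assay, for the compounds shown here, no change at the digits printed from compound 3 to compound 4 (within the scatter) is the first step that alters only the group on the carbonyl carbon while the 2-substituted ethyl chain stays in place, and it shows that diethylamino in place of methoxy there brings no response. Chain identity at the same carbonyl type is equally silent, with no change at the digits printed from compound 1 to compound 4 (within the scatter) for the pair of diethylcarbamoyl-bearing chains and no change at the digits printed from compound 2 to compound 4 (within the scatter) against the nitrile. No supporting measurement is available to account for this flat picture.

With compound 4 at 10000 nM like the other three, the compounds shown do not reveal whether any group on this chain can move the read-out. From the compounds shown here alone, a free carboxylic acid, a piperidine amide, a longer chain or a change on the shared core remain open.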